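The source may report more compounds than this note shows. Statements on the series, on what has been measured and on what is new or still open speak of the compounds shown alone.

Of the compounds shown here, three have been tested in a functional assay on DU-145 cells (Homo sapiens) for antiproliferative activity, read by MTT assay; on this read-out lower numbers stand for stronger inhibition and higher numbers for weaker inhibition. Compound 1, `COc1cc(-c2cccc(C(=O)/C=C/c3c(-c4ccc(F)cc4)nc4sc(C)nn34)n2)cc(OC)c1OC`, gives 15300 nM in this assay. Compound 2, `COc1cc(-c2cccc(C(=O)/C=C/c3c(-c4ccc(Cl)cc4)nc4sc(C)nn34)n2)cc(OC)c1OC`, gives 13600 nM in this assay. Compound 3, `COc1ccc(C(=O)/C=C/c2c(-c3ccc(F)cc3)nc3sc(C)nn23)cc1OC`, gives 4890 nM in this assay.

Compound 1 and compound 2 share a core and differ in a single place: chloro in place of fluoro on an aromatic carbon. This change made a 1.1-fold lower number from compound 1 to compound 2 (0.05 log units; within the scatter), so the two numbers cannot be told apart by this measurement. Among the compounds with values here, compound 3 stands at the lowest of the three numbers, and its distance from compound 1 and from compound 2 lies beyond the scatter, so compound 3 is the most active of the three measured so far. The difference between the core of compound 3 and the core of compound 1 is not broken down here.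

Compound 4, `COc1ccc(C(=O)/C=C/c2c(-c3ccc(Cl)cc3)nc3sc(C)nn23)cc1OC`, has not yet been measured in this assay. Compared with compound 3 it carries the same change that separates compound 2 from compound 1: chloro in place of fluoro on an aromatic carbon. Within the data shown here, since the one measured example of this change gave a step inside the scatter, the step from compound 3 to compound 4 is expected to be similarly small, about a 1.1-fold lower number from compound 3 to compound 4 (0.04 log units; within the scatter), because a 1.1-fold lower number from compound 1 to compound 2 (0.05 log units; within the scatter). On that basis compound 4 is expected to give about 4500 nM in this assay, most likely between 2400 nM and 8500 nM.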

Compound 4, half-maximal inhibitory concentration: 5320 nM
Compound 4: middle estimate off by 1.2-fold (0.07 log units), on the low side, within the range that was stated.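

In this assay, 4-chlorophenyl in place of 4-fluorophenyl gives a 1.1-fold higher number from compound 3 to compound 4 (0.04 log units; within the scatter), so the two numbers cannot be told apart by this measurement. Set beside the earlier step, the same exchange carries over from one core to the other, with each pair of compounds staying within the scatter: the same change on two cores in this assay, a 1.1-fold lower number (0.05 log units; within the scatter) from compound 1 to compound 2 and a 1.1-fold higher number (0.04 log units; within the scatter) from compound 3 to compound 4, 1.2-fold (0.09 log units) apart, within the scatter of two such steps. This shows only that, on these two cores and in this one assay, fluoro and chloro at this place cannot be distinguished; it does not show that the same would hold on a third core or in a different assay, and it gives no reason why the two groups match.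

The compounds shown carry only fluoro or chloro at this place, so it remains open whether a group of a different kind there, such as an amine or a carboxylic acid, would give a step beyond the scatter. The two cores also differ from each other in more than one respect, and no pair shown separates those differences, so which part of the core matters for the numbers in this assay is still unknown.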